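Swapping an Aminomethoxyphenyl Group for an Aminopyridine

A few compounds are considered here, and "the series" means these few. Any claim that something is new, unique, unknown or untested is made for them only; others in the source may bear on it.

Compound 2 `COc1ccc(CNS(=O)(=O)N2CCN(/C(C=N)=C(\OCC3(C)CC3)C(=O)Nc3cccc(Cl)c3)CC2)cc1N` was run in an ADME assay on the whole organism (plasma) for pharmacokinetics, with Rattus norvegicus as the target, with a stated time of 6 h, at a dose of 10 mg/kg by the oral route (on this read-out higher numbers stand for higher exposure at the dose given and lower numbers for lower exposure), where compound 2 gives 440 ng.h/mL. Within the data shown here, that is the lower of the two numbers measured so far; the only other compound, compound 1 `Cc1ccc(CNS(=O)(=O)N2CCN(/C(C=N)=C(\OCC3(C)CC3)C(=O)Nc3cccc(Cl)c3)CC2)cc1N`, gives 1410 ng.h/mL in this assay, and the step of a 3.2-fold lower number from compound 1 to compound 2 (0.51 log units; beyond the scatter) followed a single exchange, methoxy in place of methyl on an aromatic carbon. Compound 3 `CC1(CO/C(C(=O)Nc2cccc(Cl)c2)=C(/C=N)N2CCN(S(=O)(=O)NCc3ccnc(N)c3)CC2)CC1` has not yet been measured. It differs from compound 2 in one place: 2-aminopyridin-4-yl in place of 3-amino-4-methoxyphenyl on a saturated chain carbon bound to a sulfonamide nitrogen. Among the measured compounds shown here, no measured step covers an exchange of this kind, so the only guide is that even the one change already seen moved the number in this assay beyond the usual scatter. A step of moderate size in either direction therefore seems possible, and the range below is wide to reflect that. Compound 3 is expected to give about 500 ng.h/mL, within 150 ng.h/mL to 1600 ng.h/mL. The step of a 1.1-fold higher number from compound 2 to compound 3 (0.06 log units; within the scatter) is expected to be small against that uncertainty.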

Compound 3, area under the concentration-time curve: 50 ng.h/mL
Beside the measured number, compound 3's estimate is 10-fold (1.00 log units) above it; the whole stated range lies above it.
By their numbers in this assay, from the lowest: compound 3; then compound 2; then compound 1.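

In this assay, the group on a saturated chain carbon bound to a sulfonamide nitrogen proves able to shift exposure much further than the earlier exchange showed: putting 2-aminopyridin-4-yl in place of 3-amino-4-methoxyphenyl gives an 8.8-fold lower number from compound 2 to compound 3 (0.94 log units; beyond the scatter), and putting it in place of 3-amino-4-methylphenyl gives a 28-fold lower number from compound 1 to compound 3 (1.45 log units; beyond the scatter). Among these compounds, the earlier step altered only one small group on an aromatic ring of carbon only, whereas this change replaces that ring with one holding a hetero atom and also removes the methoxy or methyl group. No measurement here accounts for the drop in exposure.

These compounds cannot separate the effect of the ring nitrogen from the loss of the methoxy or methyl group. A pyridine ring carrying a methoxy or methyl group would address that question directly.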